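The source may report more compounds than this note shows. Statements on the series, on what has been measured and on what is new or still open speak of the compounds shown alone.

Three compounds share one core and differ only in the group on the amide. Compound 1 `CCn1c(C(=O)NCCN)ccc1C(CC)(CC)c1ccc(OCCC(O)(CC)CC)c(C)c1` gives 1590 nM in a functional assay on HepG2 cells (Homo sapiens) for antiproliferative activity, read by MTT assay, with a stated time of 48 h (on this read-out higher numbers stand for weaker inhibition and lower numbers for stronger inhibition), the lowest of the two numbers shown. Compound 3 `CCn1c(C(=O)N(C)CC(=O)O)ccc1C(CC)(CC)c1ccc(OCCC(O)(CC)CC)c(C)c1` gives 5710 nM in this assay, and the step of a 3.6-fold higher number from compound 1 to compound 3 (0.56 log units; beyond the scatter) is modest. Compound 2 `CCOc1ccc(NC(=O)c2ccc(C(CC)(CC)c3ccc(OCCC(O)(CC)CC)c(C)c3)n2CC)cc1` returns only a limit in this assay, namely > 50000 nM. The step of an at least 31-fold higher number from compound 1 to compound 2 (1.49 log units; beyond the scatter) is large. Compound 4 `CCC(C)C(CO)NC(=O)c1ccc(C(CC)(CC)c2ccc(OCCC(O)(CC)CC)c(C)c2)n1CC` has not yet been measured; its change from compound 1 is 1-(hydroxymethyl)-2-methylbutyl in place of 2-aminoethyl on an amide-type nitrogen. Both measured departures from the 2-aminoethyl group raised the number, so for compound 4 a rise beyond the scatter is expected, of about a 3.8-fold higher number from compound 1 to compound 4 (0.58 log units; beyond the scatter). Compound 4 is estimated at 6000 nM, with a range from 2000 nM to 25000 nM.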

Compound 4, half-maximal inhibitory concentration: > 50000 nM
Compound 4 gave a limit, no number; the forecaster's own chance of this, stated with the estimate: 15%; at least 8.3-fold (0.92 log units) between middle value and limit.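

On the amide-type nitrogen, 1-(hydroxymethyl)-2-methylbutyl in place of 2-aminoethyl gives an at least 31-fold higher number from compound 1 to compound 4 (1.49 log units; beyond the scatter), so a non-aromatic chain with the same counted hydrogen-bond donor and acceptor can fall as far as the 4-ethoxyphenyl group did. The carboxylic acid group of compound 3 stays far ahead of this chain, with an at least 8.7-fold higher number from compound 3 to compound 4 (0.94 log units; beyond the scatter). The step from compound 2 to compound 4 cannot be read, since both give only limits: the limit of > 50000 nM in this assay, at which 2 of the 4 values shown sit.

Still open, as far as these compounds go, is whether a plain 2-hydroxyethyl group, with a hydroxyl in place of the amine, would hold the activity of compound 1. Equally open, from the compounds shown here alone, is whether an unbranched hexyl chain carrying a terminal amine would do so.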